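Indole and phenyl thioacrylic acids against calpain-1

The compounds below may be only part of what the source reports. "The series", "measured", "known", "first", "only" and "open" are said of these compounds alone.

Measured so far in an assay on isolated protein for inhibition of Calpain-1 catalytic subunit (Sus scrofa), read by FRET; on this read-out higher numbers stand for weaker inhibition and lower numbers for stronger inhibition:
compound 1, `O=C(O)/C(S)=C/c1c[nH]c2cc(Cl)ccc12`, gives 210 nM
compound 2, `O=C(O)/C(S)=C/c1c[nH]c2cc(I)ccc12`, gives 170 nM
compound 3, `O=C(O)/C(S)=C/c1cccc(I)c1`, gives 4300 nM

Compound 3 stands apart from compound 1 and compound 2; the difference between the two cores is not broken down here. Within the core of compound 2, the change chloro in place of iodo on an aromatic carbon gave the step of a 1.2-fold higher number from compound 2 to compound 1 (0.09 log units; within the scatter).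

Compound 4, `O=C(O)/C(S)=C/c1cccc(Cl)c1`, not yet measured, carries the same kind of change on the core of compound 3: chloro in place of iodo on an aromatic carbon. The place is not identical: in compound 4 the ring is of carbon only and the site is meta to a group of 6 heavy atoms, whereas in compound 1 the ring is part of a fused or bridged system of two rings, meta and para to a fused ring.

Going by the values given here, on the single step seen, the number for compound 4 is expected to move little from compound 3, about a 1.2-fold higher number from compound 3 to compound 4 (0.07 log units; within the scatter), because a 1.2-fold higher number from compound 2 to compound 1 (0.09 log units; within the scatter) lay within the scatter. Compound 4 is therefore estimated at 5000 nM in this assay.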

Compound 4, half-maximal inhibitory concentration: 4200 nM
Beside the measured number, compound 4's estimate is 1.2-fold (0.08 log units) above it, within the range that was stated.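

In this assay chloro in place of iodo on an aromatic carbon gives a 1.0-fold lower number from compound 3 to compound 4 (0.01 log units; within the scatter) and so, as on the other core, no step beyond the scatter. The change therefore carries from one core to the other without a detectable difference: the same change on two cores in this assay, a 1.2-fold higher number (0.09 log units; within the scatter) from compound 2 to compound 1 and a 1.0-fold lower number (0.01 log units; within the scatter) from compound 3 to compound 4, 1.3-fold (0.10 log units) apart, within the scatter of two such steps

This rests on two pairs and one swap of halogens, and it shows neither why the two halogens read alike nor that any other replacement would carry across these cores in the same way.

Open, going by these compounds, is whether fluoro, methoxy or an amine on that aromatic carbon would also leave the number unmoved. Also open, on these data alone, is whether an ester in place of the carboxylic acid would hold the inhibition on either core.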